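Hydroxy for chloro on the imine aryl of compound 2

The compounds below may be only part of what the source reports. "The series", "measured", "known", "first", "only" and "open" are said of these compounds alone.

Measured compounds:
compound 1, `Clc1ccc(/C=N/c2sc3c(c2-c2nc4ccccc4s2)CCC3)c(Cl)c1`, 160 ug/mL in an ADME assay on cells (Rhabdomyosarcoma cell, Homo sapiens) for cytotoxicity, read by MTT assay, with a stated time of 72 h; a higher number here means that more compound is tolerated, a lower number that less compound is tolerated
compound 2, `Clc1ccccc1/C=N/c1sc2c(c1-c1nc3ccccc3s1)CCCC2`, 332 ug/mL in this assay

Compound 2 holds the highest of the two numbers in this assay; the nearest is compound 1, whose number is lower by an amount beyond the usual scatter. The two differ in more than one place, so their values are simply shown side by side and no single step can be read from them.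

Compound 3, `Oc1ccccc1/C=N/c1sc2c(c1-c1nc3ccccc3s1)CCCC2`, is not yet measured. It differs from compound 2 by hydroxy in place of chloro on an aromatic carbon. Going by the values given here, no measured pair shows this change, so the size of the step in this assay is unknown; the working expectation is a step not beyond the scatter, in either direction. The expected step is a 1.1-fold lower number from compound 2 to compound 3 (0.04 log units; within the scatter). The estimate for compound 3 is 300 ug/mL, with a range from 150 ug/mL to 600 ug/mL, anchored on compound 2 because compound 2 gives 332 ug/mL.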

Compound 3, half-maximal cytotoxic concentration: 42.4 ug/mL
For compound 3 the middle estimate is 7.1-fold (0.85 log units) above the measured one; the measured number lies below the stated range.
By their numbers in this assay, from the lowest: compound 3; then compound 1; then compound 2.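

In this assay, the change from 2-chlorophenyl to 2-hydroxyphenyl gives a 7.8-fold lower number from compound 2 to compound 3 (0.89 log units; beyond the scatter), so this aromatic carbon, ortho to a large group, is sensitive to the exchange of a single heavy atom while the rest of the structure stays the same. Hydroxy brings a hydrogen-bond donor and a hydrogen-bond acceptor that chloro lacks, but a single pair cannot show whether that difference is connected with the lower number. No measurement at hand bears on the reason for the step.

As far as these compounds go, it remains open whether the step tracks hydroxy itself or the departure of chloro, and a methoxy group or an amine on this aromatic carbon would help separate those two readings. From the compounds shown here alone, it is also open whether the same exchange would give a step of similar size on the core of compound 1, which differs from compound 2 in more than one place and so offers no direct comparison.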